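The compounds below may be only part of what the source reports. "The series", "measured", "known", "first", "only" and "open" are said of these compounds alone.

Measured in a functional assay on HCT-116 cells (Homo sapiens) for antiproliferative activity, with a stated time of 72 h; a higher number here means a weaker inhibitor, a lower number a stronger inhibitor:
- Compound 1 `Nc1ncnn2c([C@@H]3O[C@H](CO)[C@@H](O)[C@H]3O)cc(-c3ccccc3)c12`: 82600 nM
- Compound 2 `Nc1ncnn2c([C@@H]3O[C@H](CO)[C@@H](O)[C@H]3O)cc(-c3ccc(F)cc3)c12`: 42500 nM
- Compound 3 `Cc1ccccc1-c1cc([C@@H]2O[C@H](CO)[C@@H](O)[C@H]2O)n2ncnc(N)c12`: > 100000 nM, which is a limit of the assay

Compound 1 sits in a weak range alongside compound 2, and the two cannot be told apart: a 1.9-fold lower number from compound 1 to compound 2 (0.29 log units; within the scatter). The next compound, compound 4 `Nc1ncnn2c([C@@H]3O[C@H](CO)[C@@H](O)[C@H]3O)cc(/C=C/c3ccccc3)c12`, replaces the phenyl group of compound 1 with 2-phenylethenyl: 2-phenylethenyl in place of phenyl on an aromatic carbon.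

The nearest guides are small changes on that same phenyl group. Fluoro in place of hydrogen gives a 1.9-fold lower number from compound 1 to compound 2 (0.29 log units; within the scatter), and methyl in place of hydrogen gives an at least 1.2-fold higher number from compound 1 to compound 3 (0.08 log units; that floor lies within the scatter). The comparison of the two substituted compounds gives an at least 2.3-fold higher number from compound 2 to compound 3 (0.37 log units; beyond the scatter), and it rests on a limit. Among the measured compounds shown here, no measured step adds a double bond outside aromatic rings, so this guidance is loose.

No step beyond the scatter is therefore expected in this assay, and the estimated step is a 1.7-fold lower number from compound 1 to compound 4 (0.22 log units; within the scatter). Compound 4 could also end at the limit of > 100000 nM in this assay, at which 1 of the 3 values shown sits. For compound 4 the estimated value is 50000 nM, with an expected range from 12000 nM to 100000 nM.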

Compound 4, half-maximal inhibitory concentration: 4800 nM
Compound 4: middle estimate off by 10-fold (1.02 log units), on the high side; the whole stated range lies above it.
By their numbers in this assay, from the lowest: compound 4; then compounds 2 and 1 (each within the scatter of the next). At a limit, above all of these: compound 3.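

Among the compounds shown here, at this position, 2-phenylethenyl in place of phenyl, which adds a double bond outside aromatic rings, is the first change to give a large step in this assay: a 17-fold lower number from compound 1 to compound 4 (1.24 log units; beyond the scatter), and against the fluoro compound an 8.9-fold lower number from compound 2 to compound 4 (0.95 log units; beyond the scatter), so the small changes on the phenyl group did not show how much this position can respond. The value of compound 3, > 100000 nM, is a limit of the assay. The step measured against it is therefore only a floor, an at least 20-fold lower number from compound 3 to compound 4 (1.31 log units; beyond the scatter), and nothing shown here accounts for the gain.

For the compounds shown here, compound 4 is the only compound here that carries this group, so whether the double bond or the added carbons matter more stays open. A 2-phenylethyl group, the same chain without the double bond, would separate the two.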